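Swapping the Amide Aryl Group in a Phosphodiesterase Series

The source may hold more compounds than are shown below. What is called first, only, known or untested is meant among the compounds shown, and "the series" means these compounds.

Compound 3 `O=C(Nc1c(F)cccc1F)c1cn(Cc2c(F)cccc2F)c2ccc(=O)[nH]c2c1=O` stands at the edge of what an in vitro assay on Sf21 cells for inhibition of high affinity 3',5'-cyclic-AMP phosphodiesterase 7A (Homo sapiens), read by scintillation proximity assay, with a stated time of 30 min (a higher number here means a weaker inhibitor, a lower number a stronger inhibitor), reports: its value of > 1000 nM is a limit, not a number (the limit of > 1000 nM in this assay, at which 1 of the 3 values shown sits). In this assay compound 1 `CCN(CC)c1ccc(NC(=O)c2cn(Cc3c(F)cccc3F)c3ccc(=O)[nH]c3c2=O)cc1` gives 46 nM and compound 2 `N#Cc1ccc(NC(=O)c2cn(Cc3c(F)cccc3F)c3ccc(=O)[nH]c3c2=O)cc1` gives 96 nM. The change to compound 4 `COc1cc(NC(=O)c2cn(Cc3c(F)cccc3F)c3ccc(=O)[nH]c3c2=O)cc(OC)c1` is 3,5-dimethoxyphenyl in place of 2,6-difluorophenyl on an amide-type nitrogen. Among the measured compounds shown here, two measured steps bear on it, both arriving at compound 3 from the other side: an at least 21-fold higher number from compound 1 to compound 3 (1.33 log units; beyond the scatter) and an at least 10-fold higher number from compound 2 to compound 3 (1.01 log units; beyond the scatter). Since compound 4 leaves the 2,6-difluorophenyl behind, a large step back toward lower numbers is expected, estimated at an at least 6.6-fold lower number from compound 3 to compound 4 (0.82 log units; beyond the scatter). Compound 4 is therefore expected to give about 150 nM in this assay, within a range of 40 nM to 600 nM.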

Compound 4, half-maximal inhibitory concentration: 212 nM
Compound 4: middle estimate off by 1.4-fold (0.15 log units), on the low side; the measured number falls inside the stated range.
By their numbers in this assay, from the lowest: compound 1; then compound 2; then compound 4. At a limit, above all of these: compound 3.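

In this assay, moving from the 2,6-difluorophenyl to the 3,5-dimethoxyphenyl on the amide nitrogen brings the series back to a measurable number, with an at least 4.7-fold lower number from compound 3 to compound 4 (0.67 log units; beyond the scatter). The value for compound 3 remains only a limit of the assay: the limit of > 1000 nM in this assay, at which 1 of the 4 values shown sits. Even so, the 3,5-dimethoxyphenyl does not match the other two aryl groups, with a 2.2-fold higher number from compound 2 to compound 4 (0.34 log units; beyond the scatter) and a 4.6-fold higher number from compound 1 to compound 4 (0.66 log units; beyond the scatter).

Going by these compounds, it remains open whether a single methoxy group, a morpholine or a carboxylic acid on this aryl ring would bring the number down to that of compound 1. On these data alone, whether a plain alkyl chain could replace the aryl ring also remains open.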